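From isopropyl to methylsulfanyl on a shared core

This account rests on a few compounds, and the source may have more. Where it says the series, first, only, none or still open, it means among the compounds named here.

Compound 1, `O=c1c(-c2nn[nH]n2)c[nH]c2c(Br)cccc12`, gives in a functional assay on the whole organism (strain Sprague-Dawley) for inhibition, with Rattus norvegicus as the target (on this read-out higher numbers stand for an effect only at larger amounts of compound and lower numbers for an effect already at smaller amounts), only a limit of > 10 mg/kg.
Compound 2, `O=c1c(-c2nn[nH]n2)c[nH]c2c(C(F)(F)F)cccc12`, gives in this assay only a limit of > 25 mg/kg.
Compound 3, `CC(C)c1cccc2c(=O)c(-c3nn[nH]n3)c[nH]c12`, gives in this assay 10 mg/kg.

For the measured compounds named here, compound 3 thus stands as the only real number among the three values shown, the other two being limits, as recorded in the limit of > 10 mg/kg in this assay, at which 1 of the 3 values shown sits, and (the limit of > 25 mg/kg in this assay, at which 1 of the 3 values shown sits). The change to compound 4, `CSc1cccc2c(=O)c(-c3nn[nH]n3)c[nH]c12`, is methylsulfanyl in place of isopropyl on an aromatic carbon. Of the measured steps, the two that end at compound 3 concern the isopropyl group: an at least 2.5-fold lower number from compound 2 to compound 3 (0.39 log units; beyond the scatter), and a number no higher from compound 1 to compound 3 (the limit leaves the size open). The remaining step, a step that the two limits leave unreadable from compound 1 to compound 2, does not touch it. None of these steps involves methylsulfanyl, so they give no direct guide to its effect; they only show that the isopropyl compound reaches a lower number than the trifluoromethyl compound. The step in this assay is therefore expected to be a 1.5-fold higher number from compound 3 to compound 4 (0.18 log units; within the scatter), with no clear direction beyond the scatter, and a real chance that compound 4 returns only a limit. Compound 4 is estimated at 15 mg/kg, in a range from 5 mg/kg to 40 mg/kg.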

Compound 4, minimum effective dose: 25 mg/kg
The estimate for compound 4 lay 1.7-fold (0.22 log units) below the measured number, and the stated range covers the measured number.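

In this assay, methylsulfanyl in place of isopropyl at this position on the shared core gives a 2.5-fold higher number from compound 3 to compound 4 (0.40 log units; beyond the scatter), so a larger amount of compound is needed before the effect appears; the two groups are therefore not interchangeable here, even though they are swapped at a single place. For the compounds shown here, compound 2 carries only a limit, and against it the change is a number no higher from compound 2 to compound 4 (the limit leaves the size open); neither that step nor the one linking compound 1 to compound 4 can be read for size, as each involves a limit. The compounds shown give no measured property that would account for the difference between isopropyl and methylsulfanyl.

Still open, going by these compounds, is whether another group at this position, such as ethyl, methoxy or an amine, would bring the number below that of compound 3 at 10 mg/kg. Also open, on these data alone, is whether a longer chain on the sulfur, such as ethylsulfanyl, would move the number of compound 4 in either direction.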